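Phenyl for Trifluoromethyl: a Step Near the Limit

This account rests on a few compounds, and the source may have more. Where it says the series, first, only, none or still open, it means among the compounds named here.

Compound 3 `Oc1cc(O)cc(-c2cn(-c3ccc(OC(F)(F)F)cc3)nn2)c1` was tested in a functional assay on MDA-MB-231 cells (Homo sapiens) for cytotoxicity, read by MTT assay (on this read-out higher numbers stand for weaker inhibition and lower numbers for stronger inhibition), where it gives only a limit of the assay, > 10000 nM. Compound 2 `COc1ccc(-c2cn(-c3ccc(Oc4ccccc4)cc3)nn2)cc1O` also reaches only a limit in this assay, > 10000 nM. For compound 1 `COc1cc(-c2cn(-c3ccc(Oc4ccccc4)cc3)nn2)ccc1O` the result in this assay stands as "not determined" (no result reported). Among the compounds with values here, two of the three values thus sit at the same edge (the limit of > 10000 nM in this assay, at which 2 of the 3 values shown sit), so no step between measured compounds can be read. Compound 4 `Oc1cc(O)cc(-c2cn(-c3ccc(Oc4ccccc4)cc3)nn2)c1` is not yet measured; it differs from compound 3 by phenyl in place of trifluoromethyl on an oxygen on an aromatic ring. Compound 2 already carries phenoxy and gives > 10000 nM, so no change beyond the scatter is expected. The step is estimated as a step that the limit leaves unreadable from compound 3 to compound 4. Compound 4 is expected at about 15000 nM, within 5000 nM to 50000 nM.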

Compound 4, half-maximal inhibitory concentration: > 10000 nM
Compound 4 gave a limit, no number (the forecaster's own chance of this, stated with the estimate: 80%); the middle value does not contradict the limit.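

No step to compound 4 can be read from compound 2 or compound 3, because the values stop at the same limit: the limit of > 10000 nM in this assay, at which 3 of the 4 values shown sit.

As far as these compounds go, what the change from trifluoromethoxy to phenoxy does in this assay stays open.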